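Cytotoxicity in the naphthyloxyacetohydrazone series: compound 3 to compound 4

A few compounds are considered here, and "the series" means these few. Any claim that something is new, unique, unknown or untested is made for them only; others in the source may bear on it.

Measured compounds:
- compound 1 `O=C(COc1cccc2ccccc12)N/N=C/c1ccc(Cl)cc1`: 100 ug/mL
- compound 2 `O=C(COc1cccc2ccccc12)N/N=C/c1ccc(O)cc1`: 20 ug/mL
- compound 3 `C/C(=N\NC(=O)COc1cccc2ccccc12)c1cccc([N+](=O)[O-])c1`: 20 ug/mL

In an ADME assay on HEL cells (Homo sapiens) for cytotoxicity (a lower number here means that less compound is tolerated, a higher number that more compound is tolerated), compound 3 gives 20 ug/mL. It stands level with compound 2 at the digits given, and together these two carry the lowest numbers of the three; compound 1 gives 100 ug/mL, the highest number of the set.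

The next compound, compound 4 `C/C(=N\NC(=O)COc1cccc2ccccc12)c1ccccc1Br`, is not yet measured in this assay. It differs from compound 3 in one place:
2-bromophenyl in place of 3-nitrophenyl on a carbon with a double bond to nitrogen

Among the compounds with values here, only one step between measured compounds has been quantified, a 5.0-fold lower number from compound 1 to compound 2 (0.70 log units; beyond the scatter). That step concerns an exchange of a halogen for a hydroxy group on the aromatic ring attached to the imine carbon, and it ran toward a lower number. Within the data shown here, the change from compound 3 to compound 4 is not the same: a nitrophenyl is replaced by a bromophenyl, and no step of this kind is available. Still, the halogen-bearing compound 1 carries the highest number of the set, so a move toward a higher number is expected for compound 4, of size a 2.5-fold higher number from compound 3 to compound 4 (0.40 log units; beyond the scatter). The value expected for compound 4 in this assay is 50 ug/mL, in the range 20 ug/mL to 100 ug/mL.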

Compound 4, minimum cytotoxic concentration: 20 ug/mL
For compound 4 the middle estimate is 2.5-fold (0.40 log units) above the measured one, within the range that was stated.
By their numbers in this assay, from the lowest: compounds 2, 3 and 4 (each within the scatter of the next); then compound 1.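

In this assay, 2-bromophenyl in place of 3-nitrophenyl on a carbon with a double bond to nitrogen gives no change at the digits printed from compound 3 to compound 4 (within the scatter), so this exchange leaves the read-out unmoved, even though 3-nitrophenyl carries hydrogen-bond acceptors and 2-bromophenyl carries none. Within the data shown here, the only earlier step, a 5.0-fold lower number from compound 1 to compound 2 (0.70 log units; beyond the scatter), was an exchange of hydroxy for chloro on an aromatic carbon, and the new pair shows that a halogen on the aromatic ring does not by itself go with a higher number: compound 4 bears bromine and gives 20 ug/mL. No measurement on hand speaks to why the two groups are not told apart in this read-out.

Going by these compounds, whether this place tolerates any exchange without a shift remains open, since an aminophenyl, a carboxylic acid on the phenyl ring or a plain phenyl could still move the number beyond the scatter. Also open, on these data alone, is how a longer chain in place of the saturated chain carbon would read, and whether the bromo group would give the same number on another carbon of the phenyl ring.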